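Shrinking a Ring on the Core of Compound 2

A few compounds are considered here, and "the series" means these few. Any claim that something is new, unique, unknown or untested is made for them only; others in the source may bear on it.

Of the compounds shown here, two have been measured in an assay on HEK293 cells for positive allosteric modulation of metabotropic glutamate receptor 2 (Rattus norvegicus), read by thallium flux; a lower number here means a smaller maximal response, a higher number a larger maximal response. Compound 1 `O=C(O)c1cc(-c2cccc(COc3ccc4c(c3)CN(C3CCCC3)C4=O)c2)ccc1O` gives 90.1%. Compound 2 `O=C(O)c1cc(-c2cccc(COc3ccc4c(=O)n(C5CCC5)sc4c3)c2)ccc1Cl` gives 83%, the lower of the two numbers, yet the gap to compound 1 lies within the scatter, so no order can be read from it. Compound 3 `O=C(O)c1cc(-c2cccc(COc3ccc4c(=O)n(C5CC5)sc4c3)c2)ccc1Cl` is not yet measured; it differs from compound 2 by cyclopropyl in place of cyclobutyl on an aromatic nitrogen. Among the measured compounds shown here, no measured pair shows what this change does, so compound 3 is expected to stay close to compound 2, which gives 83%. Compound 3 is estimated at 83%, between 70% and 96%. The step of no change at the digits printed from compound 2 to compound 3 (within the scatter) is expected to remain within the scatter.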

Compound 3, largest response reached (reported as percent of maximum), in percent of the reference or control that the assay uses: 70.6%
The estimate for compound 3 lay 12.4 percentage points above the measured number; the range from low to high includes it.
By their numbers in this assay, from the lowest: compound 3; then compounds 2 and 1 (each within the scatter of the next).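

In this assay, swapping cyclobutyl for cyclopropyl on the aromatic nitrogen next to the ring sulfur gives a number 12.4 percentage points lower from compound 2 to compound 3 (beyond the scatter), so this position responds to a change as small as one ring carbon. The earlier compounds shown here could not show this, as they differ in more than one place. Nothing measured here accounts for the drop. Still open, as far as these compounds go, is whether an open chain such as isopropyl, or a larger ring such as cyclohexyl, would hold the response near that of compound 2 on this core.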